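A Methoxy Tail on a Weakly Binding Core

A few compounds are considered here, and "the series" means these few. Any claim that something is new, unique, unknown or untested is made for them only; others in the source may bear on it.

Measured so far in an assay on HEK293 cells for displacement of a labelled ligand from Neuronal acetylcholine receptor; alpha3/beta4 (Rattus norvegicus), with a stated time of 4 h; on this read-out higher numbers stand for weaker inhibition and lower numbers for stronger inhibition:
Compound 1 `CCO[C@H]1CC[C@H]2CCN(C)[C@H]2C1`: 300000 nM
Compound 2 `CN1CC[C@@H]2CC[C@H](OCc3ccccc3)C[C@@H]21`: 100000 nM
Compound 3 `CCO[C@H]1CC=C2CCN(C)[C@H]2C1`: > 300000 nM, a limit of the assay and not a number

All three compounds share one core. In this assay compound 3 gives only > 300000 nM, which is a limit of the assay rather than a measured number; it sits at the limit of > 300000 nM in this assay, at which 1 of the 3 values shown sits. Among the compounds with values here, the only step recorded in one place is a 3.0-fold lower number from compound 1 to compound 2 (0.48 log units; beyond the scatter), a change that does not touch the part altered here. Compound 4 `COCCO[C@H]1CC=C2CCN(C)[C@H]2C1` differs from compound 3 by methoxy in place of hydrogen on a saturated chain carbon, two bonds along the chain from an oxygen on a saturated carbon. Within the data shown here, no measured step bears on this change, so the data give no direction; the expected step is a number no higher from compound 3 to compound 4 (the limit leaves the size open), none beyond the scatter. For compound 4 the estimate is 300000 nM, with a range from 100000 nM to 1000000 nM, and a real chance that only a limit is reported again.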

Compound 4, inhibition constant: > 300000 nM
Compound 4 gave a limit, no number; the forecaster's own chance of this, stated with the estimate: 60%; the middle value lies on the limit itself.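

Within the data shown here, compound 3 and compound 4 each give only a limit of the assay, not a number, and no step between them can be read. Going by these compounds, whether the methoxy tail changes inhibition at all stays open.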